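Swapping a fluorophenyl for a nitrophenyl on the shared core

The source may report more compounds than this note shows. Statements on the series, on what has been measured and on what is new or still open speak of the compounds shown alone.

Compound 2 `C[C@H]1CC[C@@H]2[C@@H](OC(=O)[C@]23CC(c2cccc(F)c2)N(c2ccccc2)O3)[C@]2(C)C(=O)C=C[C@@]12O` and compound 1 `C[C@H]1CC[C@@H]2[C@@H](OC(=O)[C@]23CC(c2c(F)cccc2F)N(c2ccccc2)O3)[C@]2(C)C(=O)C=C[C@@]12O` share a core and differ only in the aryl group on a saturated ring carbon. In a physicochemical assay for lipophilicity (a lower number here means a more polar compound, a higher number a more lipophilic compound), compound 1 gives 3.42, and compound 2 gives 3.35, the lower of the two numbers, though the step of a number 0.07 log units lower from compound 1 to compound 2 (within the scatter) lies within the scatter. Compound 3 `C[C@H]1CC[C@@H]2[C@@H](OC(=O)[C@]23CC(c2ccc([N+](=O)[O-])cc2)N(c2ccccc2)O3)[C@]2(C)C(=O)C=C[C@@]12O` is compound 2 with a different aryl group at the same position: 4-nitrophenyl in place of 3-fluorophenyl on a saturated ring carbon. Among the measured compounds shown here, the only measured step, from compound 1 to compound 2, concerns this same position, yet it changed neither the ring size nor the count of hydrogen-bond acceptors, so it offers little guide. Since two hydrogen-bond acceptors enter, the expected step in this assay is a modest fall, a number 0.40 log units lower from compound 2 to compound 3 (beyond the scatter). Compound 3 is therefore estimated at 2.95, within a range from 2.6 to 3.3.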

Compound 3, partition coefficient: 3.15
Estimate against measurement, compound 3: 0.20 log units below; the range from low to high includes it.
By their numbers in this assay, from the lowest: compounds 3, 2 and 1 (each within the scatter of the next).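

In this assay, 4-nitrophenyl in place of 3-fluorophenyl on the saturated ring carbon gives a number 0.20 log units lower from compound 2 to compound 3 (within the scatter) and 4-nitrophenyl in place of 2,6-difluorophenyl gives a number 0.27 log units lower from compound 1 to compound 3 (within the scatter) at the same position. The earlier step left the count of hydrogen-bond acceptors unchanged, whereas here 4-nitrophenyl brings 2 hydrogen-bond acceptors where 3-fluorophenyl has 0, and compound 3 still reads within the scatter of both compound 1 and compound 2. No separate measurement accompanies these readings to explain how close they are.

On these data alone, it remains open how the reading would respond to an aryl ring bearing an amine or a carboxylic acid, or to a longer alkyl chain in place of the aryl ring. As far as these compounds go, it also remains open whether any group at this position can give a step beyond the scatter.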